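Swapping a Carboxy Group for a Ketone Ring

This account rests on a few compounds, and the source may have more. Where it says the series, first, only, none or still open, it means among the compounds named here.

In an assay for inhibition of Tryptophan 2,3-dioxygenase (Homo sapiens), with a stated time of 1 h, tested at 10 uM (on this read-out higher numbers stand for more inhibition at the one concentration tested (going by the name of the read-out) and lower numbers for less inhibition), compound 1 `FC(F)(F)c1cccc(CNc2cc(Br)cc3[nH]ncc23)c1` gives 56%. Compound 2 `O=C(O)Nc1cccc(CNc2cc(Br)cc3[nH]ncc23)c1` carries a carboxy group instead of the trifluoromethyl group, and in this assay compound 2 is reported as "not active" (no number reported), so no single number places it. Compound 3 `O=C1CCCC(Nc2cccc(CNc3cc(Br)cc4[nH]ncc34)c2)C1` is the next step, with this change: 3-oxocyclohexyl in place of carboxy on a nitrogen on an aromatic ring. Because compound 2 stands at "not active" (no number reported) while compound 1 reaches 56%, a moderate rise from compound 2 in this assay is expected, though it may stay within the scatter. Compound 3 is estimated at 25%, with a range from 0% to 55%.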

Compound 3, a percentage reported as inhibition, at one concentration (the size of the read-out at that concentration, not a potency): 46%
Compound 3: middle estimate off by 21 percentage points, on the low side; the measured number falls inside the stated range.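

In this assay, the step reads a number 10 percentage points lower from compound 1 to compound 3 (within the scatter), so at this position on the aromatic ring, (3-oxocyclohexyl)amino and trifluoromethyl cannot be told apart. Compound 2 is reported as "not active", whereas compound 3 gives 46%, which shows that a nitrogen at this position can carry a group and still give a measurable inhibition. No measurement shown accounts for this result. As far as these compounds go, what remains open is whether the ketone of the ring matters. A plain cyclohexyl group on the same nitrogen, or a simple amine there, would address that question.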